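Hydrazone aryl swaps on a sulfonamide-triazine series

This account rests on a few compounds, and the source may have more. Where it says the series, first, only, none or still open, it means among the compounds named here.

Measured so far:
compound 1 `NS(=O)(=O)c1ccc(Nc2nc(N/N=C/c3ccc(C(F)(F)F)cc3)nc(Nc3ccccc3)n2)cc1` gives 33700 nM in a functional assay on TK-10 cells (Homo sapiens) for inhibition, read by sulforhodamine B assay, with a stated time of 48 h; a lower number here means that less compound is tolerated, a higher number that more compound is tolerated
compound 2 `Cc1nn(-c2ccccc2)cc1/C=N/Nc1nc(Nc2ccccc2)nc(Nc2ccc(S(N)(=O)=O)cc2)n1` gives 8250 nM in this assay

Compound 2 has the lowest number of the two, with compound 1 the nearest neighbour: a 4.1-fold lower number from compound 1 to compound 2 (0.61 log units; beyond the scatter). Compound 3 `NS(=O)(=O)c1ccc(Nc2nc(N/N=C/c3ccccn3)nc(Nc3ccccc3)n2)cc1` is not yet measured; it changes (pyridin-2-yl in place of 3-methyl-1-phenyl-1H-pyrazol-4-yl on a carbon with a double bond to nitrogen). Among the measured compounds shown here, only that one step bears on the new change, and it was modest, so a modest shift in either direction or none beyond the scatter is expected. On that basis, compound 3 is estimated at 18000 nM (range 5000 nM to 60000 nM), expected step a 2.2-fold higher number from compound 2 to compound 3 (0.34 log units; beyond the scatter).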

Compound 3, concentration lethal to 50% of the cells: > 100000 nM
Compound 3: only a limit was reported; the forecaster's own chance of this, stated with the estimate: 15%; at least 5.5-fold (0.74 log units) between middle value and limit.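

At this place, on a carbon with a double bond to nitrogen, pyridin-2-yl gives an at least 12-fold higher number from compound 2 to compound 3 (1.08 log units; beyond the scatter) in this assay and also an at least 2.9-fold higher number from compound 1 to compound 3 (0.47 log units; beyond the scatter), so compound 3 stands highest of the three and the group here can move the number up as well as down. For compound 3 the reported value is a limit: the limit of > 100000 nM in this assay, at which 1 of the 3 values shown sits.

Open, as far as these compounds go, is how an unsubstituted phenyl or a pyridin-4-yl would read at this place. Also open, from the compounds shown here alone, is whether the ring nitrogen of pyridin-2-yl or the absence of trifluoromethyl sets the step from compound 1.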